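Methoxy on the benzyl arm of a dinitrophenyl triazole

The source may hold more compounds than are shown below. What is called first, only, known or untested is meant among the compounds shown, and "the series" means these compounds.

Compound 1 `Cn1c(SCc2ccccc2)nnc1-c1cc([N+](=O)[O-])cc([N+](=O)[O-])c1` is the reference point of this set. In an ADME assay on HepG2 cells (Homo sapiens) for cytotoxicity, with a stated time of 48 h (a higher number here means a weaker inhibitor, a lower number a stronger inhibitor), compound 1 reaches only the limit of the assay, > 30000 nM, and no number is known for it. Compound 2 `CCCCCCn1c(SCc2ccccc2)nnc1-c1cc([N+](=O)[O-])cc([N+](=O)[O-])c1` carries a pentyl in place of hydrogen on the saturated chain carbon bound to the aromatic nitrogen; in this assay compound 2 likewise gives only the limit > 30000 nM. Compound 3 `O=[N+]([O-])c1cc(-c2nnc(SCc3ccccc3)n2Cc2ccccc2)cc([N+](=O)[O-])c1` carries a phenyl at the same position; in this assay compound 3 again gives only the limit > 30000 nM. The steps that connect them are therefore unreadable: a step that the two limits leave unreadable from compound 1 to compound 2, a step that the two limits leave unreadable from compound 1 to compound 3 and a step that the two limits leave unreadable from compound 2 to compound 3 all run between two limits, as the limit of > 30000 nM in this assay, at which 3 of the 3 values shown sit, records.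

Compound 4 `COc1ccc(CSc2nnc(-c3cc([N+](=O)[O-])cc([N+](=O)[O-])c3)n2C)cc1` differs from compound 1 by methoxy in place of hydrogen on an aromatic carbon. For the measured compounds named here, none of the measured steps touches this position, and none of them yields a readable size, so no direction beyond the scatter can be taken from them. Compound 4 is therefore expected to behave like compound 1 and to stay at the limit in this assay, with an estimated step that the limit leaves unreadable from compound 1 to compound 4. Compound 4 is expected to give 50000 nM, in the range from 20000 nM to 200000 nM.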

Compound 4, half-maximal inhibitory concentration: > 30000 nM
Compound 4: no number, only a limit; the forecaster's own chance of this, stated with the estimate: 85%; the middle value does not contradict the limit.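

In this assay compound 4 gives > 30000 nM, a limit and not a number, so no new step can be read between it and compound 1, which also stands at a limit: the limit of > 30000 nM in this assay, at which 4 of the 4 values shown sit.

The compounds shown leave open how strongly any of them acts in this assay, and whether 4-methoxybenzyl in place of benzyl changes that at all.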